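The compounds below may be only part of what the source reports. "The series", "measured", "known", "first", "only" and "open" are said of these compounds alone.

Measured so far in an assay on isolated protein for inhibition of metabotropic glutamate receptor 5 (Homo sapiens), tested at 10 uM; on this read-out higher numbers stand for more inhibition at the one concentration tested (going by the name of the read-out) and lower numbers for less inhibition:
compound 1 `Cc1ccc(NC(=O)NCc2ccc(N3C(=O)C4CC=CCC4C3=O)cc2)cc1C` — < 35%
compound 2 `Cc1ccc(C(=O)COC(=O)c2ccc(N3C(=O)COCC3=O)cc2)cc1C` — 41%

Compound 1 in this assay gives < 35%, which is a limit of the assay and not a number. Going by the values given here, compound 2 in this assay gives 41%, the only number. Compound 1 sits at the limit (the limit of < 35% in this assay, at which 1 of the 2 values shown sits). Compound 3 `Cc1ccc(C(=O)COC(=O)c2ccc(N3C(=O)C4=C(CCC4)C3=O)cc2)cc1C` is not yet measured. It differs from compound 2 by a group of 10 heavy atoms (7 carbon, 1 nitrogen, 2 oxygen; one five-membered non-aromatic ring of carbon only, one five-membered non-aromatic ring with 1 hetero atom) in place of a group of 8 heavy atoms (4 carbon, 1 nitrogen, 3 oxygen; one six-membered non-aromatic ring with 2 hetero atoms), on an aromatic carbon. Without any measured step of this kind, no change beyond the scatter is expected, and the estimated step of a number 1 percentage points lower from compound 2 to compound 3 (within the scatter) is taken as small. Compound 3 is expected near 40%, between 20% and 60%.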

Compound 3, a percentage reported as inhibition, at one concentration (the size of the read-out at that concentration, not a potency): 10%
The estimate for compound 3 lay 30 percentage points above the measured number; the measured number lies below the stated range.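

In this assay, 3,5-dioxomorpholin-4-yl giving way to the group with two five-membered non-aromatic rings, on an aromatic carbon para to a large group, gives a number 31 percentage points lower from compound 2 to compound 3 (beyond the scatter). Going by these compounds alone, this position is therefore sensitive to the group it carries, which the earlier compounds, lacking any pair that differs in one place, could not show. Nothing measured here accounts for the step.

From the compounds shown here alone, whether ring size or the ring hetero atoms matter more stays open, as both change in this single step. Going by these compounds, how an amine or a carboxylic acid would read at this position also stays open.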